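Aryl substituents on the ethoxy-pyridine core: toward compound 4

The source may hold more compounds than are shown below. What is called first, only, known or untested is meant among the compounds shown, and "the series" means these compounds.

The parent compound 1 `CCOc1cccnc1Nc1cccc(C)n1` gives 40 nM in an assay on Ltk cells with metabotropic glutamate receptor 5 (Homo sapiens) as the target, read by fluorescence and calcium flux; a higher number here means a weaker inhibitor, a lower number a stronger inhibitor. Compound 2 `CCOc1cc(-c2cccc(F)c2)cnc1Nc1cccc(C)n1` gives 126 nM and compound 3 `CCOc1cc(-c2ccsn2)cnc1Nc1cccc(C)n1` gives 243 nM. The steps are a 3.2-fold higher number from compound 1 to compound 2 (0.50 log units; beyond the scatter) and a 6.1-fold higher number from compound 1 to compound 3 (0.78 log units; beyond the scatter), while a 1.9-fold higher number from compound 2 to compound 3 (0.29 log units; within the scatter). Compound 3 thus holds the highest of the three numbers, within the scatter of compound 2 and beyond it only against compound 1.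

Compound 4 `CCOc1cc(-c2cccnc2)cnc1Nc1cccc(C)n1` differs from compound 3 by pyridin-3-yl in place of 1,2-thiazol-3-yl on an aromatic carbon. Within the data shown here, the one step that bears on it, a 1.9-fold higher number from compound 2 to compound 3 (0.29 log units; within the scatter), stayed within the scatter when one aryl group replaced another at this position, so no step beyond the scatter is expected here; a number near compound 2 or compound 3 is expected for compound 4, 160 nM (range 60 nM to 420 nM), meaning an expected 1.5-fold lower number from compound 3 to compound 4 (0.18 log units; within the scatter).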

Compound 4, half-maximal inhibitory concentration: 12 nM
For compound 4 the middle estimate is 13-fold (1.12 log units) above the measured one; the measured number lies below the stated range.
By their numbers in this assay, from the lowest: compound 4; then compound 1; then compounds 2 and 3 (each within the scatter of the next).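

Aryl groups are not interchangeable at this position: pyridin-3-yl gives a far lower number than either 1,2-thiazol-3-yl (a 20-fold lower number from compound 3 to compound 4 (1.31 log units; beyond the scatter)) or 3-fluorophenyl (an 11-fold lower number from compound 2 to compound 4 (1.02 log units; beyond the scatter)), so the closeness of those two groups does not extend to every aryl group. Replacing hydrogen here can also lower the number (a 3.3-fold lower number from compound 1 to compound 4 (0.52 log units; beyond the scatter)), whereas both earlier aryl groups raised it. No available evidence bears on the reason for this difference.

On these data alone, it remains open whether the gain is specific to pyridin-3-yl or extends to pyridin-4-yl. Also open, as far as these compounds go, is how a non-aromatic group, such as morpholine or a primary amine, would behave at this position.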